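A few compounds are considered here, and "the series" means these few. Any claim that something is new, unique, unknown or untested is made for them only; others in the source may bear on it.

Measured so far in a physicochemical assay for solubility, with a stated time of 4 h, at pH 7.4; a lower number here means a less soluble compound, a higher number a more soluble compound:

Compound 1 `Cc1cc(/C=C/C#N)cc(C)c1Oc1cc(Nc2ccc(C#N)cc2)c(N)cc1C(N)=O` gives 0.63 ug/mL
Compound 2 `Cc1cc(C#N)cc(C)c1Oc1cc(Nc2ccc(C#N)cc2)c(N)cc1C(F)(F)F` gives 0.26 ug/mL

Of these two numbers, compound 1 holds the higher one. The gap between compound 1 and compound 2 lies beyond the usual scatter of repeated measurements. Both compounds are measured, but they do not differ in just one place, so no measured single change is available to serve as a guide.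

Compound 3 `CNC(=O)c1cc(N)c(Nc2ccc(C#N)cc2)cc1Oc1c(C)cc(/C=C/C#N)cc1C` has not yet been measured. Its difference from compound 1 is methyl in place of hydrogen on an amide-type nitrogen and in words it is methyl in place of hydrogen on an amide-type nitrogen, which also reads as carbamoyl to methylcarbamoyl. The rest of the structure stays the same.

The expectation therefore rests on compound 1 at 0.63 ug/mL and on the modest size of this change. In this assay the expected size of a 1.1-fold higher number from compound 1 to compound 3 (0.05 log units; within the scatter) stays within the scatter, so no real shift in either direction is foreseen. For compound 3 the estimate is 0.7 ug/mL with an expected range of 0.25 ug/mL to 2.5 ug/mL once the measurement is made.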

Compound 3, solubility: 1.32 ug/mL
Compound 3: the middle estimate sits 1.9-fold (0.28 log units) below what was measured; measured number inside the range.
By their numbers in this assay, from the lowest: compound 2; then compound 1; then compound 3.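

Going by these compounds alone, compound 3 gives the first single change that can be read in this set: replacing the amide hydrogen with methyl, which turns carbamoyl into methylcarbamoyl, produces in this assay a 2.1-fold higher number from compound 1 to compound 3 (0.32 log units; beyond the scatter). The rest of the structure stays the same, so this step belongs to one place, the amide-type nitrogen whose other neighbour is the carbonyl carbon, whereas compound 1 and compound 2 differ in more than one place and could not isolate any change. The step is called modest, yet it shows that one added carbon at this nitrogen can move the number beyond the usual scatter, although no measurement here explains the rise.

As far as these compounds go, a single methyl gives only one point on this nitrogen, so it remains open whether an ethyl group, a second methyl on the same nitrogen or a longer chain ending in an amine would raise the number further, leave it unchanged or lower it. From the compounds shown here alone, it also remains open whether the same methyl step would give a similar result on a different core.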